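Butylamino to pentylsulfanyl on a shared core

A few compounds are considered here, and "the series" means these few. Any claim that something is new, unique, unknown or untested is made for them only; others in the source may bear on it.

Going by the values given here, compound 1 `CCCCNc1nc(N)c2nc(O)n(Cc3ccccc3)c2n1` is the one compound in this set that returns a number in a functional assay (spleen, spleen) for activation, with Mus musculus as the target; on this read-out lower numbers stand for an effect already at smaller amounts and higher numbers for an effect only at larger amounts of compound: compound 1 gives 1 uM. Compound 2 `Nc1ncnc2c1nc(Cl)n2Cc1ccccc1` reaches only a limit of the assay, > 10 uM. Compound 3 `Nc1ncnc2c1nc(O)n2C1CCCC1` likewise stops at a limit, > 10 uM. Among the compounds with values here, compound 1 therefore stands alone against (the limit of > 10 uM in this assay, at which 2 of the 3 values shown sit), and since no two measured compounds differ in a single place, no measured step exists to lean on.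

Compound 4 `CCCCCSc1nc(N)c2nc(O)n(Cc3ccccc3)c2n1` has not yet been measured in this assay. It differs from compound 1 in one spot: pentylsulfanyl in place of butylamino on an aromatic carbon. The butylamino group gives way to a pentylsulfanyl group on the aromatic carbon between two ring nitrogen atoms of the shared core, with the benzyl and hydroxy groups of compound 1 kept in place.

Within the data shown here, with no measured step to guide the size, the account expects a step of no change at the digits printed from compound 1 to compound 4 (within the scatter), not beyond the usual scatter. Compound 4 is estimated at 1 uM, with a range from 0.2 uM to 5 uM.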

Compound 4, minimum effective concentration: 10 uM
Compound 4: the middle estimate sits 10-fold (1.00 log units) below what was measured; measured number above the stated range.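

Replacing butylamino with pentylsulfanyl on the aromatic carbon between two ring nitrogen atoms gives, in this assay, a 10-fold higher number from compound 1 to compound 4 (1.00 log units; beyond the scatter). This first single-place step shows that the read-out responds to the group at this position, and that the exchange, which takes the hydrogen-bond donors of the group from 1 to 0, leaves a compound that needs more material to show an effect. Compound 4 still returns a number rather than a limit, yet that number stands at the edge of what the assay reports: the limit of > 10 uM in this assay, at which 2 of the 4 values shown sit.

The compounds shown leave open whether the sulfur, the loss of the donor or the longer chain carries the step, as all three change at once. A pentylamino or a butylsulfanyl group at this position would begin to separate them.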